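A Bromo Group Enters the Core of Compound 2

A few compounds are considered here, and "the series" means these few. Any claim that something is new, unique, unknown or untested is made for them only; others in the source may bear on it.

Of the compounds shown here, two have been measured in a functional assay on U-251 cells (Homo sapiens) for inhibition, read by sulforhodamine B assay, with a stated time of 48 h; on this read-out higher numbers stand for weaker inhibition of growth and lower numbers for stronger inhibition of growth. Compound 1 `COc1ccc(/C=C/c2cc(=O)cco2)cc1OC` gives 339 uM in this assay, and compound 2 `COc1ccc(C2CC(=O)C=CO2)cc1` gives 226 uM. Compound 2 has the lowest of these two numbers, but compound 1 sits only a little higher, and the gap between them lies within the usual scatter of repeated measurements, so on these numbers the two cannot be told apart. Going by the values given here, no pair of measured compounds differs in only one place, so no single structural step has yet been measured.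

Compound 3 `COc1ccc(C2CC(=O)C(Br)=CO2)cc1` is not yet measured. It differs from compound 2 in one place: bromo in place of hydrogen on a double-bonded ring carbon. Nothing measured here speaks to a change of this kind, so the expectation rests on the number for compound 2 alone. The step of a 1.9-fold lower number from compound 2 to compound 3 (0.27 log units; within the scatter) is expected to be a modest one toward stronger inhibition of growth, near the edge of the scatter. Compound 3 is therefore expected to give about 120 uM in this assay, with a range from 40 uM to 300 uM.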

Compound 3, concentration for growth inhibition (reported as GI): 46.4 uM
Compound 3: the middle estimate sits 2.6-fold (0.41 log units) above what was measured, and the stated range covers the measured number.
By their numbers in this assay, from the lowest: compound 3; then compounds 2 and 1 (each within the scatter of the next).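

Bromo in place of hydrogen on a double-bonded ring carbon gives a 4.9-fold lower number from compound 2 to compound 3 (0.69 log units; beyond the scatter) in this assay, so this one position, two ring bonds from the ring oxygen, can change the read-out by more than the usual scatter. Going by these compounds alone, this is the first single change whose size can be read, since the earlier compounds offered no pair differing in only one place and their two numbers could not be told apart. The step shows that a single heavy atom placed here, with no ring, no charge and no hydrogen-bond donor or acceptor counted on it, is enough to move the number toward stronger inhibition of growth, but no measurement at hand gives a reason for that shift.

On these data alone, with only bromo at this position, it remains open whether the gain belongs to bromo in particular or would also appear with another group here, such as chloro, methyl, an amine or a carboxylic acid. As far as these compounds go, it also remains open whether the same change would have a similar effect on the core of compound 1.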